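The source may hold more compounds than are shown below. What is called first, only, known or untested is meant among the compounds shown, and "the series" means these compounds.

Measured in an assay on CHO cells for displacement of a labelled ligand from adenosine receptor A3 (Homo sapiens), read by scintillation counting, with a stated time of 120 min, tested at 10 uM; on this read-out lower numbers stand for less inhibition and higher numbers for more inhibition at the one concentration tested (going by the name of the read-out):
- compound 1, `Nc1scc(CN2CCN(c3cc(Cl)cc(Cl)c3)CC2)c1C(=O)c1ccc(Cl)cc1`, gives 1%
- compound 2, `Nc1scc(CN2CCN(c3ccccc3C(F)(F)F)CC2)c1C(=O)c1ccc(Cl)cc1`, gives 0%
- compound 3, `Nc1scc(CN2CCN(c3c(F)cc(F)cc3F)CC2)c1C(=O)c1ccc(Cl)cc1`, gives 0%

All three share one core and differ only in the aryl group on the amine nitrogen of the six-membered non-aromatic ring with two nitrogens. Compound 3 stands level with compound 2 at the digits shown in this assay, and its separation from compound 1 is a number 1 percentage points lower from compound 1 to compound 3 (within the scatter), which is within the scatter; none of the three gives appreciable inhibition at the concentration tested.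

Compound 4, `Nc1scc(CN2CCN(c3cc(Cl)ccc3Cl)CC2)c1C(=O)c1ccc(Cl)cc1`, has not yet been measured. It differs from compound 3 in one place: 2,5-dichlorophenyl in place of 2,4,6-trifluorophenyl on an amine nitrogen in a ring.

Among the compounds with values here, the steps that bear on this change are the exchanges of the aryl group on that ring nitrogen, a number 1 percentage points lower from compound 1 to compound 2 (within the scatter), a number 1 percentage points lower from compound 1 to compound 3 (within the scatter) and no change at the digits printed from compound 2 to compound 3 (within the scatter). Each of them lies within the scatter, so the three aryl groups tried so far are indistinguishable in this assay. On that basis the step to compound 4 is expected to be a number 1 percentage points higher from compound 3 to compound 4 (within the scatter), with no movement beyond the scatter in either direction. Compound 4 is therefore estimated to give 1% in this assay, in the range -6% to 9%.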

Compound 4, a percentage reported as inhibition, at one concentration (the size of the read-out at that concentration, not a potency): 1%
Beside the measured number, compound 4's estimate shows no gap at the digits printed; the measured number falls inside the stated range.
By their numbers in this assay, from the lowest: compounds 2, 3, 1 and 4 (each within the scatter of the next).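

In this assay the entry of 2,5-dichlorophenyl on the amine nitrogen in the ring gives a number 1 percentage points higher from compound 3 to compound 4 (within the scatter) and a number 1 percentage points higher from compound 2 to compound 4 (within the scatter) and no change at the digits printed from compound 1 to compound 4 (within the scatter) and so adds a fourth aryl group to the three that could not be told apart. The last of these steps is the new kind of comparison, since 2,5-dichlorophenyl and 3,5-dichlorophenyl carry the same two chlorine atoms in different places on the phenyl ring, and that rearrangement stays within the scatter, as does the exchange of the three fluorine atoms of 2,4,6-trifluorophenyl for the two chlorine atoms. Nothing measured here offers a reason for this flat picture.

As far as these compounds go, all four aryl groups are phenyl rings bearing chlorine, fluorine or trifluoromethyl, so it stays open whether a phenyl ring bearing a methoxy group, a hydroxyl group or an amine, or a pyridine ring, on that nitrogen would move the number beyond the scatter. From the compounds shown here alone, it is equally open whether a change elsewhere on the shared core, such as an amide in place of its free amino group, would give appreciable inhibition at the one concentration tested.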